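Aryl halide shift in the shared-core series

This account rests on a few compounds, and the source may have more. Where it says the series, first, only, none or still open, it means among the compounds named here.

The compounds share one core and differ only in the aryl group on a saturated ring carbon. Compound 1 `COC(=O)C1=C(C)N=C(C)/C(=C(\O)OC)C1c1ccccc1OC` gives 57.5 nM in a functional assay (muscle tissue) with Cavia porcellus as the target; a higher number here means that more compound is needed for the effect, a lower number that less compound is needed. Compound 2 `COC(=O)C1=C(C)N=C(C)/C(=C(\O)OC)C1c1ccccc1Br` gives 7.59 nM. Compound 3 `COC(=O)C1=C(C)N=C(C)/C(=C(\O)OC)C1c1ccc(Br)cc1` gives 540 nM, the highest of the three numbers: both a 9.4-fold higher number from compound 1 to compound 3 (0.97 log units; beyond the scatter) and a 71-fold higher number from compound 2 to compound 3 (1.85 log units; beyond the scatter) run upward to it, so the 4-bromophenyl compound needs the most material of the three.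

Compound 4 `COC(=O)C1=C(C)N=C(C)/C(=C(\O)OC)C1c1cccc(I)c1` is not yet measured; it differs from compound 3 by 3-iodophenyl in place of 4-bromophenyl on a saturated ring carbon. The step that bears most directly is a 71-fold higher number from compound 2 to compound 3 (1.85 log units; beyond the scatter), which shows the gap between 2-bromophenyl and 4-bromophenyl; a 7.6-fold lower number from compound 1 to compound 2 (0.88 log units; beyond the scatter) shows bromo outdoing methoxy within the same aryl group. Among the compounds with values here, no measured pair contains a 3-iodophenyl or any iodine, so the expectation rests only on leaving the 4-bromophenyl pattern that gave the weakest result. The step is expected to be a 27-fold lower number from compound 3 to compound 4 (1.43 log units; beyond the scatter), a lower number. Compound 4 is therefore estimated at 20 nM, within 4 nM to 100 nM.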

Compound 4, half-maximal effective concentration: 41.7 nM
Estimate against measurement, compound 4: 2.1-fold (0.32 log units) below, and the stated range covers the measured number.
By their numbers in this assay, from the lowest: compound 2; then compounds 4 and 1 (each within the scatter of the next); then compound 3.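

In this assay the 3-iodophenyl group on the saturated ring carbon gives a 13-fold lower number from compound 3 to compound 4 (1.11 log units; beyond the scatter) and so shows that a halogen on this aryl group does not by itself bring the high number of compound 3. Against the 2-bromophenyl group the change gives a 5.5-fold higher number from compound 2 to compound 4 (0.74 log units; beyond the scatter) and leaves compound 2 with the lowest number of the series, while against the 2-methoxyphenyl group it gives a 1.4-fold lower number from compound 1 to compound 4 (0.14 log units; within the scatter) and does not separate the two groups. No measurement is available here that explains these differences among the aryl groups.

Compound 3 and compound 4 differ in both the halogen and its place on the aryl group, so neither change can be read alone. As far as these compounds go, how an aryl group carrying an amine or a carboxylic acid behaves at this saturated ring carbon remains open.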